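Propylsulfanyl Gives Way to (4-Fluorophenyl)carbonyl

A few compounds are considered here, and "the series" means these few. Any claim that something is new, unique, unknown or untested is made for them only; others in the source may bear on it.

Compound 1 `COC(=O)Nc1nc2cc(Oc3cccc(N4CCN(C)CC4)n3)ccc2[nH]1`: 98.1%
Compound 2 `CCCSc1ccc2[nH]c(NC(=O)OCCCN(C)C)nc2c1`: 95.5%
Compound 3 `CCCSc1ccc2[nH]c(NC(=O)OC3COC3)nc2c1`: 95.2%

These three compounds were tested in a functional assay on PC-3 cells (Homo sapiens) for cytotoxicity, read by MTT assay, with a stated time of 72 h, tested at 1 uM (on this read-out higher numbers stand for a weaker effect at the one concentration tested and lower numbers for a stronger effect), and all three leave the cells almost untouched. Compound 2 stands second highest of the three numbers; its nearest neighbour is compound 3 and its furthest is compound 1, and both gaps lie within the scatter. Among the measured compounds shown here, the only one-place step among the measured compounds is a number 0.3 percentage points lower from compound 2 to compound 3 (within the scatter), which swaps the group on the oxygen next to the carbonyl group and changes nothing that can be told from noise.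

Compound 4 `CN(C)CCCOC(=O)Nc1nc2cc(C(=O)c3ccc(F)cc3)ccc2[nH]1` has not yet been measured. It differs from compound 2 as follows: (4-fluorophenyl)carbonyl in place of propylsulfanyl on an aromatic carbon. For the measured compounds named here, no measured step alters this part of the shared core, so nothing among the data points to a change in either direction; the one step that exists concerns a different part of the molecule and stays within the scatter. Compound 4 is therefore expected to read much like compound 2, with a step of a number 1.5 percentage points lower from compound 2 to compound 4 (within the scatter) in this assay, which is within the scatter. The estimate for compound 4 in this assay is 94%, in a range from 78% to 100%.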

Compound 4, a percentage reported as activity, at one concentration (the size of the read-out at that concentration, not a potency): 105%
For compound 4 the middle estimate is 11 percentage points below the measured one; measured number outside the range, above it.
By their numbers in this assay, from the lowest: compounds 3, 2, 1 and 4 (each within the scatter of the next).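

In this assay, among the compounds shown here, replacing the propylsulfanyl chain, which has no ring, with (4-fluorophenyl)carbonyl, which brings a six-membered aromatic ring and a carbonyl, gives a number 9.5 percentage points higher from compound 2 to compound 4 (within the scatter), the first look at a change on this aromatic carbon of the shared core rather than on the oxygen next to the carbonyl group. Even this large change in the group's size and shape leaves a reading that cannot be told from that of compound 2, so at the one concentration tested the cells show no effect that can be traced to this position, and the exchange neither adds nor removes any measurable cytotoxicity. No measurement on hand offers an explanation for this reading, so the result stands as an observation only.

The compounds shown leave open whether an amine or a carboxylic acid on this aromatic carbon, or a chain longer than propylsulfanyl, would move the reading beyond the usual scatter. They also leave open whether the fluorine on the phenyl ring plays any part, as a plain phenylcarbonyl group does not appear among them for comparison.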